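This account rests on a few compounds, and the source may have more. Where it says the series, first, only, none or still open, it means among the compounds named here.

Working notes on the series. In an assay on CHO-K1 cells for displacement of a labelled ligand from prostaglandin E2 receptor EP1 subtype (Homo sapiens) (a higher number here means a weaker inhibitor, a lower number a stronger inhibitor), compound 1 `O=C(O)c1nn(Cc2cc(Br)ccc2OCc2ccccc2)cc1Br` gives 457 nM. Within the data shown here, compound 2 `O=C(O)c1nn(Cc2cc(Br)ccc2OCc2ccccc2)cc1C(F)(F)F` shares the core and gives 2570 nM in this assay; the step of a 5.6-fold higher number from compound 1 to compound 2 (0.75 log units; beyond the scatter) is the only single-point change measured so far. Compound 3 `Cc1cc(C(=O)O)nn1Cc1cc(Br)ccc1OCc1ccc(F)cc1F` gives 0.525 nM in this assay and stands lowest of the three numbers, beyond the scatter from both compound 1 and compound 2.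

Compound 4 `Cc1cc(C(=O)O)nn1Cc1cc(Br)ccc1OCc1c(F)cccc1F` differs from compound 3 by 2,6-difluorophenyl in place of 2,4-difluorophenyl on a saturated chain carbon bound to an oxygen on an aromatic ring. Among the measured compounds shown here, no measured step in the set touches this part of the molecule; the one step measured concerns a substituent on the core and gives no guide to the change from 2,4-difluorobenzyl to 2,6-difluorobenzyl. The expectation therefore rests on compound 3 alone, and no step beyond the scatter is expected in this assay. The step expected is a 1.9-fold higher number from compound 3 to compound 4 (0.28 log units; within the scatter). For compound 4 the estimated value in this assay is 1 nM, within a range from 0.2 nM to 5 nM.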

Compound 4, half-maximal inhibitory concentration: 14.8 nM
For compound 4 the middle estimate is 15-fold (1.17 log units) below the measured one, outside the stated range (above it).
By their numbers in this assay, from the lowest: compound 3; then compound 4; then compound 1; then compound 2.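

The change from 2,4-difluorobenzyl to 2,6-difluorobenzyl keeps the same atoms, yet it gives a 28-fold higher number from compound 3 to compound 4 (1.45 log units; beyond the scatter) in this assay, the first step read at this part of the molecule. This step is larger than the only earlier one, a 5.6-fold higher number from compound 1 to compound 2 (0.75 log units; beyond the scatter), which was on the core, so the placing of the two fluorines on this ring alone can shift the number beyond the scatter. Nothing available accounts for the size of this step.

The compounds shown leave open how other groups at this place, such as 2,4-dichlorophenyl or a pyridine ring, would compare with 2,4-difluorophenyl on the core of compound 3. Compound 3 also differs from compound 1 in more than one place, so the gap between them cannot be assigned to any single change.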